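Removing the bromine from compound 1

The source may hold more compounds than are shown below. What is called first, only, known or untested is meant among the compounds shown, and "the series" means these compounds.

Of the compounds shown here, three have been measured in an ADME assay on isolated protein for inhibition of Amine oxidase [flavin-containing] B (Homo sapiens); on this read-out higher numbers stand for weaker inhibition and lower numbers for stronger inhibition. Compound 1 `C#CCNC1CCc2c(SCc3ccc(Br)cc3)cccc21` gives 488 nM, the lowest of the three numbers. Compound 2 `C#CCNC1CCc2c(SCCc3cccc(Br)c3)cccc21` gives 620 nM, which lies within the scatter of compound 1. Compound 3 `C#CCNC1CCc2c(SCCc3cccc(OC)c3)cccc21` gives 3820 nM, the highest of the three. For the measured compounds named here, the only single-place step among them, a 6.2-fold higher number from compound 2 to compound 3 (0.79 log units; beyond the scatter), shows that exchanging the bromo for a methoxy group on the aromatic carbon raises the number beyond the scatter.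

Compound 4 `C#CCNC1CCc2c(SCc3ccccc3)cccc21` differs from compound 1 by hydrogen in place of bromo on an aromatic carbon. Going by the values given here, no measured pair shows a bromo removed to leave hydrogen, so the bromo-to-methoxy step of compound 2 to compound 3 is the closest guide, and it points toward a higher number when the bromo is lost. The change here is smaller than that one, so the expected step in this assay is a 2.5-fold higher number from compound 1 to compound 4 (0.39 log units; beyond the scatter), toward weaker inhibition. Compound 4 is therefore expected to give about 1200 nM, in the range 450 nM to 3500 nM.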

Compound 4, half-maximal inhibitory concentration: "not active" (no number reported)
For compound 4 the study gives words and no number, and the estimate cannot be compared.
By their numbers in this assay, from the lowest: compounds 1 and 2 (each within the scatter of the next); then compound 3.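

In this assay, for the compounds shown here, compound 4 is reported only as "not active", without a number, and no step from compound 1 to compound 4 can be read. Nothing measured here bears on this result. The compounds shown leave open how far 4-bromophenyl to phenyl moves the number in this assay.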